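The compounds below may be only part of what the source reports. "The series", "measured", "known", "first", "only" and "open" are said of these compounds alone.

Of the compounds shown here, three have so far been tested in a functional assay on L1210 cells (Mus musculus) for antiproliferative activity; on this read-out higher numbers stand for weaker inhibition and lower numbers for stronger inhibition. Compound 1 `C/C(=C\Cc1ccc(C(N)=O)[nH]1)CCC(=O)O` gives > 100000 nM, which is a limit of the assay and not a number. Compound 2 `C/C(=C\Cc1cccc(C(N)=O)n1)CCC(=O)O` gives > 100000 nM, again a limit. Compound 3 `C/C(=C\Cn1cnc(C(N)=O)n1)CCC(=O)O` gives > 100000 nM, also a limit. Compound 3 thus shares (the limit of > 100000 nM in this assay, at which 3 of the 3 values shown sit).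

Compound 4 `C/C(=C\Cn1cnc(C(=O)O)n1)CCC(=O)O` differs from compound 3 in one place: hydroxy in place of amino on a carbonyl carbon, with hydroxy in place of amino on a carbonyl carbon, so carbamoyl becomes carboxy. Compound 3 offers only > 100000 nM as a starting point, so no step beyond the usual scatter is expected in this assay, and no direction can be given. The estimated change is a number no higher from compound 3 to compound 4 (the limit leaves the size open). For compound 4 the expected value is 100000 nM, with an estimated range of 40000 nM to 250000 nM.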

Compound 4, half-maximal inhibitory concentration: > 100000 nM
Compound 4: only a limit was reported; the forecaster's own chance of this, stated with the estimate: 90%; the middle value sits exactly at the limit.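

No step can be read from compound 3 to compound 4, as both values are limits and not numbers: the limit of > 100000 nM in this assay, at which 4 of the 4 values shown sit. The compounds shown leave open whether carbamoyl or carboxy makes any difference to inhibition.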